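The source may report more compounds than this note shows. Statements on the series, on what has been measured and on what is new or still open speak of the compounds shown alone.

Measured compounds in a functional assay on CHO cells for agonist activity at adenosine receptor A1 (Homo sapiens), read by fluorescence and ERK phosphorylation, with stated times of 30 min and 1.5 h, tested at 3 uM; on this read-out higher numbers stand for a stronger effect at the one concentration tested and lower numbers for a weaker effect:
Compound 1 `COc1cccc(-c2csc(N)c2C(=O)c2ccccc2)c1` — 41%
Compound 2 `Nc1scc(-c2cccc(F)c2)c1C(=O)c1ccc(Cl)cc1` — 76%
Compound 3 `Nc1scc(-c2cccc([N+](=O)[O-])c2)c1C(=O)c1ccc(Cl)cc1` — 53%

Compound 3 stands second highest of the three numbers. Its nearest neighbour is compound 1, lower by a gap beyond the scatter; the furthest is compound 2, higher by a gap beyond the scatter. Among the compounds with values here, the only step between measured compounds that differ in one place is a number 23 percentage points lower from compound 2 to compound 3 (beyond the scatter).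

Within the data shown here, compound 4 `COc1cccc(-c2csc(N)c2C(=O)c2ccc(Cl)cc2)c1` is the next compound to be measured. methoxy in place of nitro on an aromatic carbon Compound 1 and compound 4 both carry methoxy but differ in another part of the molecule, for which no step is measured, so compound 1 gives only a loose anchor. The step from compound 2 to compound 3 shows that an exchange at this position moves the number modestly; the reverse exchange, nitro to methoxy, is a new one. The step is expected to be a number 2 percentage points higher from compound 3 to compound 4 (within the scatter), small and of uncertain direction. Compound 4 is estimated at 55%, with a range from 38% to 72%.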

Compound 4, a percentage reported as activity, at one concentration (the size of the read-out at that concentration, not a potency): 58%
Estimate against measurement, compound 4: 3 percentage points below; the measured number falls inside the stated range.
By their numbers in this assay, from the lowest: compound 1; then compounds 3 and 4 (each within the scatter of the next); then compound 2.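

Working from this assay, methoxy in place of nitro gives a number 5 percentage points higher from compound 3 to compound 4 (within the scatter), so the two groups are not told apart at this position, whereas methoxy in place of fluoro gives a number 18 percentage points lower from compound 2 to compound 4 (beyond the scatter), which leaves fluoro apart from both. Within the data shown here, in another part of the molecule, with methoxy held constant, chloro in place of hydrogen on an aromatic carbon gives a number 17 percentage points higher from compound 1 to compound 4 (beyond the scatter), the first measured step for that change. No measured evidence on the compounds accounts for these steps.

From the compounds shown here alone, it remains open whether an amine, a hydroxyl or a longer chain such as ethoxy at this position would fall with fluoro or with methoxy and nitro. The chloro step is shown only with methoxy in place, so its size with fluoro or nitro at this position remains open as well.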